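This account rests on a few compounds, and the source may have more. Where it says the series, first, only, none or still open, it means among the compounds named here.

Measured in an ADME assay on CCRF-CEM cells (Homo sapiens) for cytotoxicity, with a stated time of 3 days; a higher number here means that more compound is tolerated, a lower number that less compound is tolerated:
compound 1 `Cc1cc(C)cc(Cn2c(=O)cc(C)n(C3C=CC(OC(=O)c4ccccc4)C3)c2=O)c1`: 25000 nM
compound 2 `O=C(OC1C=CC(n2ccc(=O)n(C(=O)c3ccccc3)c2=O)C1)c1ccccc1`: >= 250000 nM (a limit)
compound 3 `O=C(OC1C=CC(n2ccc(=O)[nH]c2=O)C1)c1ccccc1`: > 250000 nM (a limit)

Compound 3 has no number, only the limit > 250000 nM. Compound 4 `Cc1cc(C)cc(Cn2c(=O)ccn(C3C=CC(OC(=O)c4ccccc4)C3)c2=O)c1` departs from it by one change: 3,5-dimethylbenzyl in place of hydrogen on an aromatic nitrogen. For the measured compounds named here, the only measured step on an aromatic nitrogen is a step that the two limits leave unreadable from compound 2 to compound 3, so it sets no size. Compound 1 also carries 3,5-dimethylbenzyl and gives 25000 nM, though its core differs from that of compound 4. On that value, a clear drop in this assay is expected, towards less compound tolerated. The estimated change is an at least 7.1-fold lower number from compound 3 to compound 4 (0.85 log units; beyond the scatter). The value expected for compound 4 is 35000 nM, with an estimated range of 12000 nM to 120000 nM.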

Compound 4, half-maximal cytotoxic concentration: 40000 nM
Compound 4: the middle estimate sits 1.1-fold (0.06 log units) below what was measured; the measured number falls inside the stated range.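

On the aromatic nitrogen, 3,5-dimethylbenzyl gives a step of readable minimum size in this assay: an at least 6.2-fold lower number from compound 3 to compound 4 (0.79 log units; beyond the scatter) against hydrogen, and an at least 6.2-fold lower number from compound 2 to compound 4 (0.79 log units; beyond the scatter) against benzoyl. Both steps start from limits, so each gives only a minimum, and the step between those two limit compounds cannot be read. With 3,5-dimethylbenzyl in place, a methyl on the aromatic carbon makes no difference beyond the scatter: a 1.6-fold higher number from compound 1 to compound 4 (0.20 log units; within the scatter). Open, on these data alone, is whether unsubstituted benzyl on this nitrogen would give the same drop. As far as these compounds go, a longer alkyl chain or a carboxylic acid there also remains open.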